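The source may hold more compounds than are shown below. What is called first, only, known or untested is meant among the compounds shown, and "the series" means these compounds.

Compound 1, `CN(C)C(=S)N/N=C/c1ccc2ccccc2n1`, is a thiosemicarbazone carrying a dimethylamino group on its thiocarbonyl carbon. For the measured compounds named here, in a functional assay on HT-29 cells (Homo sapiens) for antiproliferative activity, read by sulforhodamine B assay, with a stated time of 72 h (a higher number here means a weaker inhibitor, a lower number a stronger inhibitor), compound 1 gives 20 nM, and this is the only actual number among the results so far. Compound 2, `NC(=S)N/N=C/c1cc2cccnc2s1`, is built on a different core and carries a plain amino group on the thiocarbonyl carbon. In this assay compound 2 reaches only > 100000 nM, which is a limit of the assay rather than a measured number; it is the limit of > 100000 nM in this assay, at which 1 of the 2 values shown sits. Compound 1 and compound 2 differ in two places at once, so their two values show only that one is a strong inhibitor and the other shows no inhibition within the range the assay covers.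

Compound 3, `NC(=S)N/N=C/c1ccc2ccccc2n1`, keeps the core of compound 1 and differs from it in one place: amino in place of dimethylamino on a thiocarbonyl carbon. Going by the values given here, no pair of measured compounds isolates this change, so its size cannot be read from the data. The expectation is that compound 3 is a weaker inhibitor, with a loss beyond the usual scatter, the expected step being a 100-fold higher number from compound 1 to compound 3 (2.00 log units; beyond the scatter). Compound 3 is estimated at 2000 nM, expected between 200 nM and 50000 nM.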

Compound 3, half-maximal inhibitory concentration: 100000 nM
Compound 3: the middle estimate sits 50-fold (1.70 log units) below what was measured; measured number above the stated range.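

In this assay, replacing dimethylamino with amino on the thiocarbonyl carbon, with the core of compound 1 unchanged, gives a 5000-fold higher number from compound 1 to compound 3 (3.70 log units; beyond the scatter). The earlier comparison changed two places at once, whereas this pair changes only one, so it shows that on this core the group on the thiocarbonyl carbon alone can separate a strong inhibitor from a very weak one. The number for compound 3 is a measured value, but it sits at the top of what the assay covers, as the one limit among the results shows: the limit of > 100000 nM in this assay, at which 1 of the 3 values shown sits.

The compounds shown leave open which part of dimethylamino matters, since nothing here sits between the two groups, such as methylamino, or goes beyond them, such as diethylamino or a piperidine ring. As far as these compounds go, it also remains open whether dimethylamino would raise activity on the core of compound 2, which appears here only with amino, so this single pair cannot be taken as a general rule.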